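This account rests on a few compounds, and the source may have more. Where it says the series, first, only, none or still open, it means among the compounds named here.

In a functional assay, tested at 200 ug/mL (on this read-out higher numbers stand for a weaker effect at the one concentration tested and lower numbers for a stronger effect), three compounds have been measured so far:

compound 1 `CCOC(=O)C1=C(C)N(c2ccccc2)C=CC1c1ccccc1` gives -29.3%
compound 2 `COC(=O)C1=C(C)N(c2ccccc2)C=CC1c1ccccc1` gives -23%
compound 3 `COC(=O)C1=C(C)N(c2ccccc2)C=C(C)C1c1ccccc1` gives -33.1%

Compound 2 holds the highest of these three numbers, yet its step to compound 1, a number 6.3 percentage points higher from compound 1 to compound 2 (within the scatter), stays within the scatter, and only its step to compound 3, a number 10.1 percentage points lower from compound 2 to compound 3 (beyond the scatter), reaches beyond it. Compound 4 `COC(=O)C1=C(C)N(c2ccccc2)C=CC1c1ccc(OC)cc1` has not been measured. It differs from compound 2 in a single place: methoxy in place of hydrogen on an aromatic carbon. Neither measured step touches the aromatic ring where this change sits: one alters the saturated chain carbon bound to an oxygen next to a carbonyl group, the other puts a methyl on a double-bonded ring carbon of the shared core. Among the compounds with values here, nothing measured therefore shows how this assay responds to a methoxy on that ring, and the only guide is the narrow spread of the three numbers. No step beyond the scatter is expected from compound 2 to compound 4: a number 2 percentage points lower from compound 2 to compound 4 (within the scatter). Compound 4 is accordingly estimated at -25%, with a likely range from -42% to -8%.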

Compound 4, a percentage reported as activity, at one concentration (the size of the read-out at that concentration, not a potency): -27.7%
The estimate for compound 4 lay 2.7 percentage points above the measured number; the range from low to high includes it.
By their numbers in this assay, from the lowest: compounds 3, 1, 4 and 2 (each within the scatter of the next, the first and the last beyond it).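

In this assay, within the data shown here, the change from phenyl to 4-methoxyphenyl gives a number 4.7 percentage points lower from compound 2 to compound 4 (within the scatter), so this is the first view of how the read-out responds to a change on this aromatic ring. A methoxy, with its 2 heavy atoms, can sit on this carbon, para to a large group, without a step beyond the scatter, and this read-out does not separate the two compounds. No available measurement offers an explanation for this result.

One substituent at one place says little about the ring as a whole, so a larger group such as butoxy, or a carboxylic acid or an amine, could behave differently here. From the compounds shown here alone, it also remains open whether a methoxy on the other aromatic ring would give a step beyond the scatter.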